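Methyl in place of methoxy on the carboxylic side chain

This account rests on a few compounds, and the source may have more. Where it says the series, first, only, none or still open, it means among the compounds named here.

For the measured compounds named here, compound 2 `COC(C(=O)O)c1nn(Cc2cn3cc(OCC4CC4)c(Cl)cc3n2)c2ccccc2c1=O` sits at the high end of the three numbers so far. In a functional assay on HFL1 cells for antagonist activity at sphingosine 1-phosphate receptor 2 (Homo sapiens), read by ELISA, with a stated time of 24 h (on this read-out higher numbers stand for weaker inhibition and lower numbers for stronger inhibition), compound 2 gives 94 nM, while compound 1 `O=C(O)Cn1nc(Cc2cn3cc(OCC4CC4)c(Cl)cc3n2)c2ccccc2c1=O` gives 7.6 nM and compound 3 `CC(C(=O)O)c1nn(Cc2cn3cc(OCC4CC4)c(C(F)(F)F)cc3n2)c2ccccc2c1=O`, which also differs elsewhere in the molecule, gives 5 nM. The change to compound 4 `C[C@H](C(=O)O)c1nn(Cc2cn3cc(OCC4CC4)c(Cl)cc3n2)c2ccccc2c1=O` is 1-carboxyethyl in place of carboxy(methoxy)methyl on an aromatic carbon. Going by the values given here, no step between measured compounds isolates this change; the nearest guide is that compound 1, lacking the methoxy group, gives 7.6 nM, and compound 3, carrying the same 1-carboxyethyl group, gives 5 nM. Compound 4 is therefore expected to lie well below compound 2, the step of a 12-fold lower number from compound 2 to compound 4 (1.07 log units; beyond the scatter) being beyond the scatter. The estimate for compound 4 in this assay is 8 nM, within 2.5 nM to 40 nM.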

Compound 4, half-maximal inhibitory concentration: 2.1 nM
Estimate against measurement, compound 4: 3.8-fold (0.58 log units) above; the measured number lies below the stated range.
By their numbers in this assay, from the lowest: compound 4; then compounds 3 and 1 (each within the scatter of the next); then compound 2.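

Taking 1-carboxyethyl in place of carboxy(methoxy)methyl on this aromatic carbon gives a 45-fold lower number from compound 2 to compound 4 (1.65 log units; beyond the scatter) in this assay. With the rest of the molecule unchanged, this side chain alone accounts for a large step. The entering group also brings a defined stereocentre, so this one step does not separate the loss of the methoxy oxygen from that stereocentre, and nothing shown gives a reason for the step's size. Still open, on these data alone, is how the mirror-image 1-carboxyethyl, a longer 1-carboxypropyl chain, or an amide in place of the carboxylic acid would read here.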